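From 3,4-difluorophenyl to 3-chlorophenyl: expecting little change

This account rests on a few compounds, and the source may have more. Where it says the series, first, only, none or still open, it means among the compounds named here.

Measured in a functional assay on HCT-116 cells (Homo sapiens) for inhibition, read by sulforhodamine B assay, with a stated time of 48 h; on this read-out higher numbers stand for weaker inhibition of growth and lower numbers for stronger inhibition of growth:
- compound 1 `CC(C)c1ccc(Nc2ccc3c(OCCCN4CCN(C)CC4)cccc3n2)cc1`: 5900 nM
- compound 2 `CN1CCN(CCCOc2cccc3nc(Nc4ccc(F)c(F)c4)ccc23)CC1`: 3800 nM

Only these two compounds have been measured, and their values lie within the usual scatter of each other. Compound 2 therefore holds no clear place ahead of compound 1.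

The next molecule, compound 3 `CN1CCN(CCCOc2cccc3nc(Nc4cccc(Cl)c4)ccc23)CC1`, differs from compound 2 in one place only: 3-chlorophenyl in place of 3,4-difluorophenyl on a nitrogen on an aromatic ring. In words, it carries 3-chlorophenyl in place of 3,4-difluorophenyl on a nitrogen on an aromatic ring.

Among the measured compounds shown here, one measured step bears on this change, as it altered the group at the same place. That step is a 1.6-fold lower number from compound 1 to compound 2 (0.19 log units; within the scatter). Swapping 4-isopropylphenyl for 3,4-difluorophenyl thus moved the number by no more than the scatter. A single step is thin evidence, but it gives no reason to predict a direction, so no shift beyond the scatter is expected in this assay.

The expected step is a 1.1-fold higher number from compound 2 to compound 3 (0.02 log units; within the scatter). For compound 3 the estimated value is 4000 nM, with an expected range from 1800 nM to 9000 nM.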

Compound 3, concentration for 50% growth inhibition: 1550 nM
For compound 3 the middle estimate is 2.6-fold (0.41 log units) above the measured one; measured number outside the range, below it.
By their numbers in this assay, from the lowest: compound 3; then compounds 2 and 1 (each within the scatter of the next).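

The group on this nitrogen does matter in this assay: the earlier swap gave a 1.6-fold lower number from compound 1 to compound 2 (0.19 log units; within the scatter) and so showed nothing clear, whereas this change gives a 2.5-fold lower number from compound 2 to compound 3 (0.39 log units; beyond the scatter) and moves the number past the scatter. The same group also separates from 4-isopropylphenyl, with a 3.8-fold lower number from compound 1 to compound 3 (0.58 log units; beyond the scatter) as the printed step, so compound 3 stands clearly ahead of both other compounds on growth inhibition, though both steps are modest. This one swap also changes more than a single atom, since the two fluorines of the 3,4-difluorophenyl group leave and the one chlorine of the 3-chlorophenyl group enters, and the gain therefore belongs to the whole exchange rather than to the chlorine alone.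

The compounds shown do not tell whether a single fluorine, a bromine or a methoxy group in place of that chlorine would hold the lower number, so the part played by the halogen itself remains open. Nothing measured here explains why the 3-chlorophenyl group gives the lower number.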